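A few compounds are considered here, and "the series" means these few. Any claim that something is new, unique, unknown or untested is made for them only; others in the source may bear on it.

Measured compounds in an assay on HEK293 cells for displacement of a labelled ligand from NPC1-like intracellular cholesterol transporter 1 (Homo sapiens); on this read-out higher numbers stand for weaker inhibition and lower numbers for stronger inhibition:
compound 1 `CC(C)(C)c1ccc(C(=O)N2CCC3(CC2)C(=O)N(CC(=O)N2CCNCC2)CN3c2ccccc2)cc1` gives 22000 nM
compound 2 `CC(C)(C)OC(=O)NCCNC(=O)CN1CN(c2ccccc2)C2(CCN(C(=O)c3ccc(C(C)(C)C)cc3)CC2)C1=O` gives 10900 nM
compound 3 `CCC1CCCN(C(=O)CN2CN(c3ccccc3)C3(CCN(C(=O)c4ccc(C(C)(C)C)cc4)CC3)C2=O)C1` gives 3900 nM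

Compound 3 stands lowest of the three numbers in this assay. Its nearest neighbour is compound 2, reached by a 2.8-fold lower number from compound 2 to compound 3 (0.45 log units; beyond the scatter); the furthest is compound 1, reached by a 5.6-fold lower number from compound 1 to compound 3 (0.75 log units; beyond the scatter). The step of a 2.0-fold lower number from compound 1 to compound 2 (0.30 log units; within the scatter) keeps those two within the scatter of one another.

Compound 4 `CC(C)(C)c1ccc(C(=O)N2CCC3(CC2)C(=O)N(CC(=O)NCCCCCNS(C)(=O)=O)CN3c2ccccc2)cc1` is the next point. Against compound 3 it shows ((5-(methanesulfonamido)pentyl)amino in place of 3-ethylpiperidin-1-yl on a carbonyl carbon).

Going by the values given here, two measured steps bear on this change. Both replace a group on the same carbonyl carbon: the piperazin-1-yl of compound 1 and the open (2-((tert-butoxycarbonyl)amino)ethyl)amino of compound 2 each lose to the 3-ethylpiperidin-1-yl of compound 3, modestly in both cases. Compound 4 carries an open chain with donors and acceptors, closer in kind to compound 2 than to compound 3, so the number is expected to move back upward, beyond the scatter, toward the region of compound 2, as a 2.3-fold higher number from compound 3 to compound 4 (0.36 log units; beyond the scatter).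

For compound 4 in this assay a value of about 9000 nM is estimated, within a range of 3500 nM to 25000 nM.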

Compound 4, half-maximal inhibitory concentration: 5500 nM
The estimate for compound 4 lay 1.6-fold (0.21 log units) above the measured number, within the range that was stated.
By their numbers in this assay, from the lowest: compounds 3, 4, 2 and 1 (each within the scatter of the next, the first and the last beyond it).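

In this assay, an open chain on this carbonyl carbon holds level with the ring: the (5-(methanesulfonamido)pentyl)amino group and the 3-ethylpiperidin-1-yl group give a 1.4-fold higher number from compound 3 to compound 4 (0.15 log units; within the scatter), so the ring of compound 3 is not required for a number in this region. The methanesulfonamide chain also stays level with the open chain ending in a tert-butoxycarbonyl amino group, a 2.0-fold lower number from compound 2 to compound 4 (0.30 log units; within the scatter), which places compound 4 within the scatter of two compounds that are themselves separated by a 2.8-fold lower number from compound 2 to compound 3 (0.45 log units; beyond the scatter). Going by these compounds alone, the only step from compound 4 beyond the scatter is the one that replaces piperazin-1-yl, a 4.0-fold lower number from compound 1 to compound 4 (0.60 log units; beyond the scatter), so the compounds with a non-piperazine group tend to sit lower than compound 1, with compound 2 going against this as it remains within the scatter of compound 1.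

As far as these compounds go, it remains open how a primary amine or a carboxylic acid at the end of the pentyl chain, or a longer chain carrying the same methanesulfonamide, would read in this assay. The data offer no measurement that accounts for any of these steps.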